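Swapping Bromo for Cyano on a Second Core

A few compounds are considered here, and "the series" means these few. Any claim that something is new, unique, unknown or untested is made for them only; others in the source may bear on it.

Four compounds share one kind of structural edit. Compound 1 `COc1cc([C@](O)(CCN(C)C)[C@@H](c2cc3cc(Br)ccc3nc2OC)c2ccnc(OC)c2OC)cc(OC(F)F)n1` and compound 2 `COc1cc([C@](O)(CCN(C)C)[C@@H](c2cc3cc(C#N)ccc3nc2OC)c2ccnc(OC)c2OC)cc(OC(F)F)n1` were both run in an ADME assay on microsomes from liver (Homo sapiens) for metabolic stability; on this read-out lower numbers stand for slow clearance and higher numbers for fast clearance: compound 1 gives 2.1 uL/min, and compound 2 gives 2.5 uL/min. The change between them is cyano in place of bromo on an aromatic carbon, and it produced a 1.2-fold higher number from compound 1 to compound 2 (0.08 log units; within the scatter).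

Compound 3 `COc1cccc([C@H](c2cc3cc(Br)ccc3nc2OC)[C@@](O)(CCN(C)C)c2cc(SC)nc(SC)c2)c1F` is built on a different core; how its core differs from the core of compound 1 is not broken down here. In this assay compound 3 gives 3.4 uL/min. Compound 4 `COc1cccc([C@H](c2cc3cc(C#N)ccc3nc2OC)[C@@](O)(CCN(C)C)c2cc(SC)nc(SC)c2)c1F` has not yet been measured. It differs from compound 3 by cyano in place of bromo on an aromatic carbon, the same change that separates compound 1 from compound 2, at a place described in the same words.

For the measured compounds named here, the expectation for the new pair rests on the only measured example of this change, because the earlier pair showed a 1.2-fold higher number from compound 1 to compound 2 (0.08 log units; within the scatter), so the expected step is a 1.1-fold higher number from compound 3 to compound 4 (0.06 log units; within the scatter). Compound 4 is therefore expected to give about 3.9 uL/min in this assay, most likely between 2.2 uL/min and 6.8 uL/min.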

Compound 4, intrinsic clearance in a liver preparation (reported as CLH), per the amount of preparation that the assay uses: 15 uL/min
The estimate for compound 4 lay 3.8-fold (0.59 log units) below the measured number; the measured number lies above the stated range.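

In this assay the same swap on the second core gives a 4.4-fold higher number from compound 3 to compound 4 (0.64 log units; beyond the scatter), so a step measured on one core did not predict the size of the step on the other. Set side by side, the two results do not agree: the same change on two cores in this assay, a 1.2-fold higher number (0.08 log units; within the scatter) from compound 1 to compound 2 and a 4.4-fold higher number (0.64 log units; beyond the scatter) from compound 3 to compound 4, 3.7-fold (0.57 log units) apart, beyond the scatter of two such steps. For the compounds shown here, this shows that, in this series, the effect of replacing bromo with cyano on clearance depends on the surrounding core, but with only two pairs it does not show which structural difference between the cores matters, why the steps differ, or what size of step a further core would give.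

The compounds shown leave open which part of the core of compound 3 goes with the larger step, since its core and that of compound 1 differ as wholes rather than in one place. They also leave open how a chloro group or a primary amide on the same aromatic carbon would read on either core.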